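The compounds below may be only part of what the source reports. "The series", "measured", "known", "first", "only" and "open" are said of these compounds alone.

Measured so far in the series:

- compound 1, `NS(=O)(=O)c1cc(-c2nnc(CN3CCN(c4ccc(F)cc4)CC3)o2)c(Cl)cc1SCc1ccccc1`: in an ADME assay on HaCaT cells (Homo sapiens) for cytotoxicity, read by MTT assay, with a stated time of 72 h (a higher number here means a weaker inhibitor, a lower number a stronger inhibitor), compound 1 gives 110000 nM
- compound 2, `NS(=O)(=O)c1cc(-c2nnc(/C=C/c3ccccc3)o2)c(Cl)cc1SCc1ccccc1`: in this assay compound 2 gives 20000 nM

Compound 2 stands at the lowest of the two numbers in this assay; its nearest neighbour is compound 1, whose number is higher by an amount beyond the usual scatter. Among the compounds with values here, no pair among the measured compounds differs in a single place, so no measured step is at hand.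

Compound 3, `NS(=O)(=O)c1cc(-c2nnc(/C=C/c3ccc(Br)cc3)o2)c(Cl)cc1SCc1ccccc1`, differs from compound 2 by bromo in place of hydrogen on an aromatic carbon. Within the data shown here, nothing among the measured compounds speaks to this change, so the expectation rests on compound 2 alone. The expected step of a 1.3-fold lower number from compound 2 to compound 3 (0.12 log units; within the scatter) is small and within the scatter, with a slight lean towards a lower number. Compound 3 is therefore estimated at 15000 nM, with a range from 5000 nM to 50000 nM.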

Compound 3, half-maximal inhibitory concentration: 31000 nM
Estimate against measurement, compound 3: 2.1-fold (0.32 log units) below; measured number inside the range.
By their numbers in this assay, from the lowest: compounds 2 and 3 (each within the scatter of the next); then compound 1.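

With this assay as the read-out, the series now has its first measured single-place change: bromo in place of hydrogen on an aromatic carbon, para to a large group, gives a 1.6-fold higher number from compound 2 to compound 3 (0.19 log units; within the scatter) and stays within the scatter. Phenyl and 4-bromophenyl at the end of the 2-phenylethenyl group therefore cannot be told apart in this assay, and this one change gives no sign that this position affects the number. Nothing on hand offers an explanation for this result.

Bromo is the only group shown at this position, so it remains open whether an amine, a carboxylic acid or a methoxy group in the same place would give a step beyond the scatter. The step from compound 1 to either ethenyl compound cannot be read, as those structures differ in more than one place.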